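The source may hold more compounds than are shown below. What is called first, only, known or untested is meant among the compounds shown, and "the series" means these compounds.

In a functional assay on A549 cells (Homo sapiens) for inhibition, read by sulforhodamine B assay, with a stated time of 48 h (on this read-out lower numbers stand for stronger inhibition and higher numbers for weaker inhibition), compound 1 (`COc1ccc(C(OCc2ccccc2)c2cccc3ccccc23)c(OC)c1OC`) gives 13500 nM and compound 2 (`COc1ccc(C(c2ccccc2O)c2cccc3ccccc23)c(OC)c1OC`) gives 13600 nM while compound 3 (`C=CCOC(c1ccc(OC)c(OC)c1OC)c1cccc2ccccc12`) gives 9710 nM in the same read-out. Compound 3 thus stands level with both others, all three numbers lying within the scatter of each other. Next in the series is compound 4 (`COc1ccc(C(OCc2ccc(C)cc2)c2cccc3ccccc23)c(OC)c1OC`), which differs from compound 3 as follows: 4-methylphenyl in place of vinyl on a saturated chain carbon bound to an oxygen on a saturated carbon. The closest measured change is the opposite kind of exchange at this place, vinyl in place of phenyl, which gave a 1.4-fold lower number from compound 1 to compound 3 (0.14 log units; within the scatter) as its size. Allyloxy in place of 2-hydroxyphenyl gave a 1.4-fold lower number from compound 2 to compound 3 (0.15 log units; within the scatter) as its size. Within the data shown here, neither step leaves the scatter, and no measured compound shows what the methyl of the 4-methylphenyl group adds. No step beyond the scatter is therefore expected in this assay for this change. The expected step is a 1.2-fold higher number from compound 3 to compound 4 (0.09 log units; within the scatter) and so stays inside the scatter. Compound 4 is estimated at 12000 nM with an expected range from 6000 nM to 24000 nM for repeated measurements.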

Compound 4, half-maximal inhibitory concentration: 15700 nM
The estimate for compound 4 lay 1.3-fold (0.12 log units) below the measured number; the range from low to high includes it.
By their numbers in this assay, from the lowest: compounds 3, 1, 2 and 4 (each within the scatter of the next).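

In this assay, the exchange of vinyl for 4-methylphenyl on a saturated chain carbon bound to an oxygen on a saturated carbon gives a 1.6-fold higher number from compound 3 to compound 4 (0.21 log units; within the scatter), so this larger aromatic group does not separate compound 4 from the allyl ether compound 3. Among these compounds, the methyl, whose contribution no earlier compound could show, gives a 1.2-fold higher number from compound 1 to compound 4 (0.07 log units; within the scatter), and (4-methylbenzyl)oxy in place of 2-hydroxyphenyl gives a 1.2-fold higher number from compound 2 to compound 4 (0.06 log units; within the scatter). All four compounds thus remain level in this assay, and no outside data bear on these steps.

On these data alone, whether any group at this place can move the number beyond the scatter stays open. An amine or a carboxylic acid in place of the methyl of the 4-methylphenyl group, or a longer chain in place of the allyl, would test this.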